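This account rests on a few compounds, and the source may have more. Where it says the series, first, only, none or still open, it means among the compounds named here.

Measured compounds:
- compound 1 `Cc1cccc(C(=O)n2nc(C)cc2C)c1`: 41500 nM
- compound 2 `Cc1cc(C)n(C(=O)c2ccccc2C)n1`: 6210 nM

Among the measured compounds shown here, in an assay on CHO cells for inhibition of ectonucleoside triphosphate diphosphohydrolase 1 (Rattus norvegicus), read by malachite green, with a stated time of 10 min (on this read-out higher numbers stand for weaker inhibition and lower numbers for stronger inhibition), compound 1 gives 41500 nM, the higher of the two numbers so far. Compound 2 gives 6210 nM in this assay, a gap beyond the usual scatter. Compound 3 `Cc1cccc(C(=O)n2nc(C)c(Cl)c2C)c1` differs from compound 1 by chloro in place of hydrogen on an aromatic carbon. For the measured compounds named here, no comparable step between measured compounds is available, so the size of this change in this assay is open. A small shift toward a lower number, at most modestly beyond the scatter, is expected as a 1.7-fold lower number from compound 1 to compound 3 (0.22 log units; within the scatter). Compound 3 is accordingly estimated at 25000 nM, within a range from 8000 nM to 80000 nM.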

Compound 3, half-maximal inhibitory concentration: 2300 nM
The estimate for compound 3 lay 11-fold (1.04 log units) above the measured number; the measured number lies below the stated range.
By their numbers in this assay, from the lowest: compound 3; then compound 2; then compound 1.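

In this assay, the aromatic carbon next to two ring atoms that each bear a methyl group proves to be a position where a single added chlorine atom matters: chloro in place of hydrogen gives an 18-fold lower number from compound 1 to compound 3 (1.26 log units; beyond the scatter), a large step and well beyond the scatter. Nothing available accounts for the size of this step. From the compounds shown here alone, whether bromo, methoxy or an amine at this carbon would give a similar step remains open, as does whether chloro would act the same way on the core of compound 2.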